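Aryl exchange on the chain: cytotoxicity, compounds 2 and 3

This account rests on a few compounds, and the source may have more. Where it says the series, first, only, none or still open, it means among the compounds named here.

Measured so far in a functional assay on PC-3 cells (Homo sapiens) for cytotoxicity, read by MTT assay, with a stated time of 72 h; on this read-out lower numbers stand for stronger inhibition and higher numbers for weaker inhibition:
compound 1 `COc1ccc(/C=C/C(=O)Nc2cc(C(=O)c3cc(OC)c(OC)c(OC)c3)ccc2OC)cc1` gives 11100 nM
compound 2 `COc1ccc(C(=O)c2cc(OC)c(OC)c(OC)c2)cc1NC(=O)/C=C/c1cccc(OC(F)(F)F)c1` gives 7700 nM

Compound 2 has the lowest of the two numbers; the nearest is compound 1, and the step between them is within the scatter, so no order between the two can be claimed. Compound 3 `COc1ccc(C(=O)c2cc(OC)c(OC)c(OC)c2)cc1NC(=O)/C=C/c1ccc([N+](=O)[O-])cc1` is not yet measured; it differs from compound 2 by 4-nitrophenyl in place of 3-(trifluoromethoxy)phenyl on a double-bonded chain carbon bound to a double-bonded chain carbon. Within the data shown here, the only measured step that bears on an aryl-for-aryl exchange at this chain position is a 1.4-fold lower number from compound 1 to compound 2 (0.16 log units; within the scatter), which stayed within the scatter. Among the measured compounds shown here, no measured step covers the 4-nitrophenyl group itself, so the expectation rests on that single exchange alone. Compound 3 is therefore expected to show a step of a 1.0-fold higher number from compound 2 to compound 3 (0.02 log units; within the scatter) in this assay, none beyond the scatter, with an estimated value of 8000 nM and a range from 3500 nM to 18000 nM.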

Compound 3, half-maximal inhibitory concentration: 10400 nM
Estimate against measurement, compound 3: 1.3-fold (0.11 log units) below; measured number inside the range.
By their numbers in this assay, from the lowest: compounds 2, 3 and 1 (each within the scatter of the next).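

In this assay, a second aryl-for-aryl exchange at this place, on a double-bonded chain carbon bound to a double-bonded chain carbon, gives a 1.4-fold higher number from compound 2 to compound 3 (0.13 log units; within the scatter). Nitro in place of methoxy on an aromatic carbon gives a 1.1-fold lower number from compound 1 to compound 3 (0.03 log units; within the scatter), so this exchange also stays within the scatter, and all three aryl groups now shown at this place give numbers that cannot be ordered, with no compound among 1, 2 and 3 going against this. No measured information on why these numbers stay together is at hand.

From the compounds shown here alone, whether an aryl group carrying an amine or a carboxylic acid, or a cyclohexyl group or longer alkyl chain in place of the aryl group, would give a step beyond the scatter remains open. Also open, going by these compounds, is how the number responds to any change elsewhere on the shared core.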